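The compounds below may be only part of what the source reports. "The series", "measured", "known", "first", "only" and "open" are said of these compounds alone.

Compound 1, with structure `CCOC(=O)c1cc(=O)c2cc(CSC(=S)N(C(C)C)C(C)C)ccc2o1`, was tested in a functional assay on LM7 cells (Homo sapiens) for antiproliferative activity, read by MTT assay, with a stated time of 72 h; on this read-out higher numbers stand for weaker inhibition and lower numbers for stronger inhibition. For compound 1 the result in this assay is a limit, > 25000 nM, and not a number. Compound 2, with structure `CC(C)N(C(=S)SCc1oc2ccccc2c(=O)c1Cl)C(C)C`, was tested in this assay as well. For compound 2 the result is also a limit, > 40000 nM, and not a number. Both values shown so far are therefore limits, and compound 1 stands among them, so no ranking between compound 1 and compound 2 is possible from these two values alone.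

Compound 3, with structure `CCOC(=O)c1cc(=O)c2cc(CSC(=S)N3CCCCC3)ccc2o1`, differs from compound 1 in one place: piperidin-1-yl in place of diisopropylamino on a thiocarbonyl carbon. Within the data shown here, since compound 1 is known only as a limit, no step between compound 1 and compound 3 can be measured from these numbers; the expected step that the limit leaves unreadable from compound 1 to compound 3 for compound 3 is estimated to lie within the usual scatter and in no particular direction. Compound 3 is therefore expected to give 30000 nM in this assay, with the estimate between 10000 nM and 100000 nM, most likely again as a limit.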

Compound 3, half-maximal inhibitory concentration: 16900 nM
For compound 3 the middle estimate is 1.8-fold (0.25 log units) above the measured one; the range from low to high includes it.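

In this assay compound 3 gives 16900 nM, the first result in this set that is a number and not a limit. With piperidin-1-yl in place of diisopropylamino on a thiocarbonyl carbon, the data show an at least 1.4-fold lower number from compound 1 to compound 3 (0.17 log units; that floor lies within the scatter), so the change can be given only a floor, and that floor does not by itself separate the two compounds. The real size of the step stays unread because compound 1 is known only as a limit: the limit of > 25000 nM in this assay, at which 1 of the 3 values shown sits.

The compounds shown leave open whether another amine on the thiocarbonyl carbon, such as pyrrolidin-1-yl, morpholin-4-yl or the open-chain diethylamino, would give a clearly lower number than compound 3 or one within the usual scatter of it. They also leave open how much the ethyl ester contributes to the value of compound 3, which a carboxylic acid or a simple amide in its place on the same core would begin to show.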